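Fluoro for Butoxy in a Cell Toxicity Series

The source may hold more compounds than are shown below. What is called first, only, known or untested is meant among the compounds shown, and "the series" means these compounds.

Measured so far:
compound 1, `CCOC(=O)c1c(-c2cc(F)cc(OC)c2)[nH]c2cc(OC)ccc2c1=O`: > 21500 nM
compound 2, `CCCCOc1cccc(-c2[nH]c3cc(OC)ccc3c(=O)c2C(=O)OCC)c1`: > 21500 nM

Compound 2 has been tested in an ADME assay on BJ cells (Homo sapiens) for cytotoxicity, read by luminescence, with a stated time of 72 h; on this read-out higher numbers stand for an effect only at larger amounts of compound and lower numbers for an effect already at smaller amounts. In this assay compound 2 gives > 21500 nM, and this is a limit of the assay, not a number. Compound 1 also gives > 21500 nM in this assay, again a limit. Both values therefore sit at the limit of > 21500 nM in this assay, at which 2 of the 2 values shown sit, so compound 2 cannot be placed above or below compound 1 on the numbers shown.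

Compound 3, `CCOC(=O)c1c(-c2cccc(F)c2)[nH]c2cc(OC)ccc2c1=O`, differs from compound 2 by fluoro in place of butoxy on an aromatic carbon. Among the measured compounds shown here, no step between two measured compounds is known here, so the size of the change cannot be read from data. In this assay the step is expected to be none beyond the scatter, with compound 3 expected to end at the limit as well. Compound 3 is expected to give about 25000 nM, with a range from 15000 nM to 50000 nM. The expected step that the limit leaves unreadable from compound 2 to compound 3 is thus within the scatter.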

Compound 3, half-maximal effective concentration: > 21500 nM
Compound 3: no number, only a limit; the forecaster's own chance of this, stated with the estimate: 80%; the middle value does not contradict the limit.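

No step can be read from compound 2 to compound 3 or from compound 1 to compound 3, because all three compounds stop at the same assay limit rather than giving a number: the limit of > 21500 nM in this assay, at which 3 of the 3 values shown sit.

Left open is how toxic each compound is to these cells, and whether swapping fluoro for butoxy or hydrogen for methoxy changes that at all.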